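From Pyrrolidin-1-yl to Phenyl on a Sulfinyl Sulfur

The source may hold more compounds than are shown below. What is called first, only, known or untested is meant among the compounds shown, and "the series" means these compounds.

Measured so far:
- Compound 1 `O=S(=NSC(F)(F)F)(c1ccccc1)N1CCOCC1`: "not determined" (no result reported)
- Compound 2 `O=S(=NSC(F)(F)F)(c1ccccc1)N1CCCC1`: 0.1 ug/mL
- Compound 3 `O=[N+]([O-])c1ccc(S(=O)(=NSC(F)(F)F)N2CCCC2)cc1`: "not determined" (no result reported)

Three compounds were tested in a functional assay on HepG2 cells (Homo sapiens) for cytotoxicity, read by spectrophotometry, with a stated time of 6 h (on this read-out higher numbers stand for lower toxicity in this test and lower numbers for higher toxicity in this test), yet only one of them came back with a number. In this assay compound 1 gives "not determined" (no result reported) and compound 3 gives "not determined" (no result reported), so compound 2 stands alone: in this assay compound 2 gives 0.1 ug/mL, which is the only number shown and therefore cannot be compared with any other measured compound.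

The compound not yet measured is compound 4 `O=S(=NSC(F)(F)F)(c1ccccc1)c1ccccc1`. It differs from compound 2 in one place: phenyl in place of pyrrolidin-1-yl on a sulfinyl sulfur. For the measured compounds named here, no pair of measured compounds shows what such a change does in this assay, so there is no step to lean on. With only compound 2 as a reference point, the expectation for compound 4 is a step of a 1.5-fold higher number from compound 2 to compound 4 (0.18 log units; within the scatter), that is, no change beyond the usual scatter. Compound 4 is thus expected to give about 0.15 ug/mL, within a range from 0.05 ug/mL to 0.5 ug/mL.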

Compound 4, minimum cytotoxic concentration: 1 ug/mL
Beside the measured number, compound 4's estimate is 6.7-fold (0.82 log units) below it, outside the stated range (above it).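

In this assay, placing phenyl in place of pyrrolidin-1-yl on a sulfinyl sulfur gives a 10-fold higher number from compound 2 to compound 4 (1.00 log units; beyond the scatter), and a higher number here stands for lower toxicity in this test. This shows that the group at this position can shift the read-out beyond the usual scatter, which a single value for compound 2 could not reveal, although the finding rests on just this one pair. Nothing available speaks to the reason for this step.

On these data alone, whether the aromatic ring itself matters remains open, since a cyclohexyl group or a simple methyl on the same sulfur would be needed to separate ring type from other differences. As far as these compounds go, it is also open how a piperidin-1-yl group or an open-chain dimethylamino group would read at this position.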